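Notes on the sulfanyl chain extension from compound 1

This account rests on a few compounds, and the source may have more. Where it says the series, first, only, none or still open, it means among the compounds named here.

Compound 1 `COc1ccc(-n2c(SC)nnc2-c2cc(OC)c(OC)c(OC)c2)cc1` is tested in a functional assay on HCT-116 cells (Homo sapiens) for inhibition, read by MTT assay, with a stated time of 48 h; on this read-out lower numbers stand for stronger inhibition and higher numbers for weaker inhibition. In this assay compound 1 gives only a limit of > 60000 nM, so no number fixes where it stands. Its nearest neighbour, compound 2 `CCSc1nnc(-c2cc(OC)c(OC)c(OC)c2)n1-c1ccc(OC)cc1`, differs by methyl in place of hydrogen on a saturated chain carbon bound to a sulfur. In this assay compound 2 likewise gives only a limit, > 60000 nM. The step that the two limits leave unreadable from compound 1 to compound 2 is therefore unreadable, and the limit of > 60000 nM in this assay, at which 2 of the 2 values shown sit, is all the series shows so far.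

The next compound, compound 3 `COc1ccc(-n2c(SCc3ccc(F)cc3)nnc2-c2cc(OC)c(OC)c(OC)c2)cc1`, carries 4-fluorophenyl in place of hydrogen on a saturated chain carbon bound to a sulfur. For the measured compounds named here, the one measured step that touches the same chain carbon has no readable size or direction, so no guide exists for this larger change. The expectation for compound 3 is a step of an at least 1.5-fold lower number from compound 1 to compound 3 (0.17 log units; that floor lies within the scatter), with a fair chance that this assay again reports only a limit. Compound 3 is estimated at 40000 nM, between 8000 nM and 200000 nM.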

Compound 3, half-maximal inhibitory concentration: 38700 nM
Compound 3: the middle estimate sits 1.0-fold (0.01 log units) above what was measured; low and high end bracket the measured number.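

For the compounds shown here, with 4-fluorophenyl on the saturated chain carbon bound to the sulfur, this assay gives the only value that is a number rather than a limit, so this position can yield a measurable read-out, with an at least 1.5-fold lower number from compound 1 to compound 3 (0.19 log units; that floor lies within the scatter). The same holds when 4-fluorophenyl takes the place of methyl at that carbon, with an at least 1.5-fold lower number from compound 2 to compound 3 (0.19 log units; that floor lies within the scatter). Both steps are floors rather than sizes, and each floor is set by a limit of the assay: the limit of > 60000 nM in this assay, at which 2 of the 3 values shown sit.

Going by these compounds, how far the true steps extend remains open, and so does whether the read-out depends on the fluorine or on the aromatic ring. A plain benzyl group, a butyl chain or a 2-aminoethyl chain on the sulfur would begin to separate these possibilities.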